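The source may report more compounds than this note shows. Statements on the series, on what has been measured and on what is new or still open speak of the compounds shown alone.

In a functional assay on A549 cells (Homo sapiens) for inhibition, read by sulforhodamine B assay, with a stated time of 48 h, tested at 50 uM (on this read-out higher numbers stand for more inhibition of growth at the one concentration tested and lower numbers for less inhibition of growth), compound 2 `COc1ccc([C@@H]2C/C(=N/OCc3cn(-c4ccc(Cl)cc4C)nn3)c3cc(CC=C(C)C)c(OC)cc3O2)cc1` gives (35%) and lies within the scatter of compound 1 `CCCOc1ccc([C@@H]2CC(=O)c3cc(CC=C(C)C)c(OC)cc3O2)cc1` at (43%). Compound 3 `C#CCOc1ccc([C@@H]2CC(=O)c3cc(CC=C(C)C)c(OC)cc3O2)cc1` at (53%) stands above compound 2 by more than the scatter, so compound 2 is separated from only one of the two.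

Compound 4 `COc1ccc([C@@H]2C/C(=N/OCc3cn(-c4ccc(C(N)=O)cc4)nn3)c3cc(CC=C(C)C)c(OC)cc3O2)cc1` keeps the rest of compound 2 and changes one group, on an aromatic nitrogen of a five-membered aromatic ring with 3 nitrogen: 4-carbamoylphenyl in place of 4-chloro-2-methylphenyl on an aromatic nitrogen.

Within the data shown here, the only measured step between close neighbours, a number 10 percentage points higher from compound 1 to compound 3 (within the scatter), lies within the scatter. It sits at another place, on a saturated chain carbon bound to an oxygen on an aromatic ring, so it gives no direct guide to this change. Among the measured compounds shown here, compound 1 and compound 3 also lack the large group that compound 2 carries, and no measured pair varies the group on the aromatic nitrogen.

With no evidence for a direction, no step beyond the scatter is expected in this assay. The estimated step is a number 2 percentage points lower from compound 2 to compound 4 (within the scatter). The expectation therefore rests on compound 2 at (35%), with a wide margin for the untested group. Compound 4 is expected at 33%, within an estimated range from 18% to 50%.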

Compound 4, percent growth inhibition at one concentration: 100%
For compound 4 the middle estimate is 67 percentage points below the measured one; measured number outside the range, above it.
By their numbers in this assay, from the lowest: compounds 2, 1 and 3 (each within the scatter of the next, the first and the last beyond it); then compound 4.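

In this assay, the group on the aromatic nitrogen of the five-membered aromatic ring with 3 nitrogen proves to be a sensitive position: 4-carbamoylphenyl in place of 4-chloro-2-methylphenyl gives a number 65 percentage points higher from compound 2 to compound 4 (beyond the scatter). Among these compounds, the earlier one-place change, at a saturated chain carbon bound to an oxygen on an aromatic ring, gave only a number 10 percentage points higher from compound 1 to compound 3 (within the scatter), so this is the first step between close neighbours to clear the scatter. The entering group carries 1 hydrogen-bond donor and 1 hydrogen-bond acceptor where the leaving group carries neither, but nothing on hand explains the size of the step.

From the compounds shown here alone, because chloro and methyl leave as the carbamoyl group enters, it remains open whether the step follows the carbamoyl group itself or the loss of those two substituents, and whether a carboxylic acid or an amine in place of the carbamoyl group would give a similar number. Among the compounds shown here, at the one concentration tested compound 4 gives 100%, so how far its growth inhibition holds at lower concentrations also remains open.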